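A few compounds are considered here, and "the series" means these few. Any claim that something is new, unique, unknown or untested is made for them only; others in the source may bear on it.

Measured compounds in an assay on microsomes for inhibition of acyl-CoA desaturase 1 (Mus musculus), with a stated time of 60 min; a lower number here means a stronger inhibitor, a higher number a weaker inhibitor:
Compound 1, `COc1ccc(C(=O)Nc2ncc(Cc3cccc(Cl)c3)s2)cc1OCCO`: compound 1 gives 1 nM
Compound 2, `COc1ccc(C(=O)Nc2ncc(Cc3cccc(C(C)(C)C)c3)s2)cc1OCCO`: compound 2 gives 1310 nM
Compound 3, `COc1ccc(C(=O)Nc2ncc(Cc3cc(Cl)cc(Cl)c3)s2)cc1OCCO`: compound 3 gives 0.7 nM

Compound 3 holds the lowest number of the three in this assay, but its gap to compound 1 is small: a 1.4-fold lower number from compound 1 to compound 3 (0.15 log units; within the scatter), which is within the scatter, so the two cannot be ranked. Compound 2 stands far apart, as a 1900-fold lower number from compound 2 to compound 3 (3.27 log units; beyond the scatter) shows.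

Compound 4, `COc1ccc(C(=O)Nc2ncc(Cc3ccc(Cl)c(Cl)c3)s2)cc1OCCO`, has not been measured. It differs from compound 3 in one place: 3,4-dichlorophenyl in place of 3,5-dichlorophenyl on a saturated chain carbon bound to an aromatic carbon. The two share every atom and differ only in where the second chlorine sits on the ring.

Going by the values given here, no measured step moves a chlorine around this ring, so none bears directly on this change. What is known is that adding a second chlorine, a 1.4-fold lower number from compound 1 to compound 3 (0.15 log units; within the scatter), changed little, while replacing the chlorine with a tert-butyl, a 1300-fold higher number from compound 1 to compound 2 (3.12 log units; beyond the scatter), was a large loss. Two chlorines are kept here, so compound 4 is expected to stay close to compound 3, with at most a modest step in this assay, and the estimate is a 2.1-fold higher number from compound 3 to compound 4 (0.33 log units; beyond the scatter). Compound 4 is therefore expected to give about 1.5 nM, within a range of 0.4 nM to 6 nM.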

Compound 4, half-maximal inhibitory concentration: 0.8 nM
Compound 4: middle estimate off by 1.9-fold (0.27 log units), on the high side; low and high end bracket the measured number.
By their numbers in this assay, from the lowest: compounds 3, 4 and 1 (each within the scatter of the next); then compound 2.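

In this assay, going by these compounds alone, the 3,4-dichlorophenyl and 3,5-dichlorophenyl groups on the saturated chain carbon cannot be told apart, at a 1.1-fold higher number from compound 3 to compound 4 (0.06 log units; within the scatter), so for this pair moving the second chlorine has no readable effect, something no earlier pair could show. The second chlorine as placed in compound 4 also stays within the scatter of the single-chlorine compound, at a 1.3-fold lower number from compound 1 to compound 4 (0.10 log units; within the scatter), while the large distance from the tert-butyl compound holds for this dichloro pattern too, at a 1600-fold lower number from compound 2 to compound 4 (3.21 log units; beyond the scatter). No evidence is available that accounts for these results.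

The compounds shown leave open whether a fluorine, a methyl, a methoxy group or a nitrile in place of a chlorine would keep this level or fall toward that of compound 2, and so where between chloro and tert-butyl the loss sets in. Also open, from the compounds shown here alone, is whether a phenyl ring carrying three chlorines would remain within the scatter of compound 3 and compound 4.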